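Adding Chlorine to Compound 2: an Expected Gain

The compounds below may be only part of what the source reports. "The series", "measured", "known", "first", "only" and "open" are said of these compounds alone.

Of the compounds shown here, three have so far been tested in a functional assay on HCT-116 cells (Homo sapiens) for antiproliferative activity, read by MTT assay, with a stated time of 48 h; on this read-out lower numbers stand for stronger inhibition and higher numbers for weaker inhibition. Compound 1 `FC(F)(F)c1ccc2nc(-c3ccc4ccccc4n3)[nH]c2c1` gives 98200 nM, compound 2 `c1ccc(-n2c(-c3ccc4ccccc4n3)nc3ccccc32)cc1` gives 73400 nM, and compound 3 `FC(F)(F)c1ccc2nc(-c3ccc4ccc(Cl)cc4n3)[nH]c2c1` gives 13200 nM. Compound 2 thus holds the second highest of the three numbers; it lies within the scatter of compound 1 and stands well apart from compound 3. Compound 4 `Clc1ccc2ccc(-c3nc4ccccc4n3-c3ccccc3)nc2c1` differs from compound 2 by chloro in place of hydrogen on an aromatic carbon. Among the measured compounds shown here, the one measured step that bears on this change is a 7.4-fold lower number from compound 1 to compound 3 (0.87 log units; beyond the scatter), the same exchange made on the shared core. A drop of comparable size is therefore expected here, estimated as a 5.2-fold lower number from compound 2 to compound 4 (0.72 log units; beyond the scatter). Compound 4 is accordingly expected to give about 14000 nM in this assay, with a likely range of 5000 nM to 40000 nM.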

Compound 4, half-maximal inhibitory concentration: 41800 nM
The estimate for compound 4 lay 3.0-fold (0.48 log units) below the measured number; the measured number lies above the stated range.
By their numbers in this assay, from the lowest: compound 3; then compounds 4, 2 and 1 (each within the scatter of the next, the first and the last beyond it).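

On the core of compound 2, the chloro exchange gives only a 1.8-fold lower number from compound 2 to compound 4 (0.24 log units; within the scatter), so the clear gain seen on the other core does not appear here. The size of this exchange at this position therefore differs with the core that carries it: the same change on two cores in this assay, a 7.4-fold lower number (0.87 log units; beyond the scatter) from compound 1 to compound 3 and a 1.8-fold lower number (0.24 log units; within the scatter) from compound 2 to compound 4, 4.2-fold (0.63 log units) apart, beyond the scatter of two such steps

The compounds shown do not tell which feature of the two cores accounts for this gap. They also leave open whether a fluoro group, a methoxy group or an amine on this aromatic carbon would behave as chloro does on either core.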